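The source may report more compounds than this note shows. Statements on the series, on what has been measured and on what is new or still open speak of the compounds shown alone.

Among the measured compounds shown here, in an assay on HEK293 cells for displacement of a labelled ligand from 5-hydroxytryptamine receptor 7 (Homo sapiens) (a lower number here means a stronger inhibitor, a higher number a weaker inhibitor), compound 2, `Cc1ccccc1N1CCN(CCn2c(=O)n(-c3ccccc3C)c3ccccc32)CC1`, gives 18000 nM, the highest of the two numbers recorded; the only neighbour, compound 1, `COc1ccc(-n2c(=O)n(CCN3CCN(c4ccccc4)CC3)c3ccccc32)cc1`, gives 566 nM, and the gap between them lies beyond the scatter. Compound 3, `Cc1ccccc1-n1c(=O)n(CCN2CCN(c3ccccc3)CC2)c2ccccc21`, differs from compound 2 by hydrogen in place of methyl on an aromatic carbon, ortho to a large group, so that a 2-methylphenyl becomes a phenyl. For the measured compounds named here, no single-point step between measured compounds exists to guide the estimate. Since compound 1, carrying the same phenyl, reaches 566 nM, a step toward a lower number is expected, of the size a 6.0-fold lower number from compound 2 to compound 3 (0.78 log units; beyond the scatter). Compound 3 is estimated at 3000 nM, between 800 nM and 10000 nM.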

Compound 3, inhibition constant: 902 nM
For compound 3 the middle estimate is 3.3-fold (0.52 log units) above the measured one, within the range that was stated.
By their numbers in this assay, from the lowest: compounds 1 and 3 (each within the scatter of the next); then compound 2.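

In this assay the change from 2-methylphenyl to phenyl gives a 20-fold lower number from compound 2 to compound 3 (1.30 log units; beyond the scatter) and so ties a large step to one methyl alone, which the earlier pair could not do. On the aromatic nitrogen, 2-methylphenyl in place of 4-methoxyphenyl gives a 1.6-fold higher number from compound 1 to compound 3 (0.20 log units; within the scatter) and so does not set these two groups apart. Nothing at hand accounts for either step. From the compounds shown here alone, whether an ethyl group or a chlorine atom in place of this methyl would give a similar step stays open. So does what a methyl elsewhere on this ring would do.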